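Methyl for hydrogen on the ring with one nitrogen

The compounds below may be only part of what the source reports. "The series", "measured", "known", "first", "only" and "open" are said of these compounds alone.

Two compounds of this set share a core, compound 1 `COc1cccc(NC(=O)Nc2ccc(Nc3ncnc4c3OCCN4)cc2)c1` and compound 2 `CC(C)(C)c1cc(NC(=O)Nc2ccc(Nc3ncnc4c3OCCN4)nc2)no1`. In an assay on isolated protein for inhibition of proto-oncogene tyrosine-protein kinase receptor Ret variant V804L (Homo sapiens), read by 33P incorporation, with stated times of 15 min and 40 min (on this read-out higher numbers stand for weaker inhibition and lower numbers for stronger inhibition), compound 1 reaches only the limit of > 10000 nM in this assay, at which 1 of the 2 values shown sits, and is reported as > 10000 nM, which is a limit of the measurement and not a number. Compound 2 is the one compound with a numerical result in this assay, where it gives 54 nM, so it stands alone as the only number shown. Compound 3 `Cc1nc(Nc2ncnc3c2OCCN3)ccc1NC(=O)Nc1cc(C(C)(C)C)on1` has not yet been measured. It differs from compound 2 by methyl in place of hydrogen on an aromatic carbon; the carbon lies on a six-membered aromatic ring with one nitrogen, next to the ring nitrogen, ortho to a large group and meta to a large group. Among the measured compounds shown here, no step between measured compounds shows this kind of change, so the expected shift from compound 2 to compound 3 is estimated as small, a 1.1-fold lower number from compound 2 to compound 3 (0.03 log units; within the scatter), with no direction beyond the usual scatter. Compound 3 is therefore expected to give about 50 nM in this assay, within a range from 15 nM to 180 nM.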

Compound 3, half-maximal inhibitory concentration: 877 nM
For compound 3 the middle estimate is 18-fold (1.24 log units) below the measured one; the whole stated range lies below it.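

In this assay, the carbon on the six-membered aromatic ring with 1 nitrogen, next to the ring nitrogen, ortho to a large group and meta to a large group, proves sensitive to substitution: methyl in place of hydrogen there brings a 16-fold higher number from compound 2 to compound 3 (1.21 log units; beyond the scatter), which is a large step. Among the compounds shown here, this is the first step in the set to test this place, and it shows that an addition of only 1 heavy atom, with no ring and no net charge, weakens inhibition markedly without removing it, since compound 3 still gives a numerical result of 877 nM. Nothing in the data given bears on why this methyl has so large an effect.

The compounds shown leave open whether the loss is particular to methyl or would also follow from a fluorine, a methoxy group or an amine on the same carbon. They also leave open whether a methyl on the other carbons of this ring would weaken inhibition to a similar degree, or at all.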